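Nitroimidazole propanol series: working notes toward compound 4

The source may report more compounds than this note shows. Statements on the series, on what has been measured and on what is new or still open speak of the compounds shown alone.

Measured so far:
compound 1 `CCN(C)C(=S)SCC(O)Cn1c([N+](=O)[O-])cnc1C` gives 4150000 nM
compound 2 `Cc1ncc([N+](=O)[O-])n1CC(O)CN1CCN(c2ncccn2)CC1` gives 3930000 nM
compound 3 `Cc1ncc([N+](=O)[O-])n1CC(O)CN1CCCC1` gives only the assay limit > 5000000 nM

In a toxicity assay on HeLa cells (Homo sapiens) for cytotoxicity, read by MTT assay, with a stated time of 24 h (a lower number here means a stronger inhibitor, a higher number a weaker inhibitor), compound 1 gives 4150000 nM. Compound 2 gives 3930000 nM in this assay, and these two values sit within the usual scatter of each other, so no order between them is claimed. For compound 3 the reading > 5000000 nM is a limit of this assay and not a number; it sits at the limit of > 5000000 nM in this assay, at which 1 of the 3 values shown sits. Compound 3 therefore stands at the weak end of what this assay can report, with the other two compounds not far off.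

Compound 4 `Cc1ncc([N+](=O)[O-])n1CC(O)Cn1ccnn1` differs from compound 3 in one place: 1H-1,2,3-triazol-1-yl in place of pyrrolidin-1-yl on a saturated chain carbon, two bonds along the chain from an oxygen on a saturated carbon. Among the measured compounds shown here, no measured step between any two compounds is available, so the expected size of the step from compound 3 to compound 4 rests only on the spread of the three values shown, which is narrow, and on the fact that compound 3 is a limit. The step of a number no higher from compound 3 to compound 4 (the limit leaves the size open) is expected to lie within the scatter, with no direction beyond it. Compound 4 is expected to give about 5000000 nM in this assay, with a range from 2500000 nM to 10000000 nM, and a real chance that only a limit is reported again.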

Compound 4, half-maximal inhibitory concentration: > 5000000 nM
Compound 4 gave a limit, no number; the forecaster's own chance of this, stated with the estimate: 60%; the middle value lies on the limit itself.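

No step can be read from compound 3 to compound 4 in this assay, because both compounds give only a limit, not a number: the limit of > 5000000 nM in this assay, at which 2 of the 4 values shown sit.

The compounds shown leave open whether 1H-1,2,3-triazol-1-yl in place of pyrrolidin-1-yl shifts the half-maximal inhibitory concentration at all, and in which direction.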